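Aryl substituent changes on the cyclopropane amide series

The source may hold more compounds than are shown below. What is called first, only, known or untested is meant among the compounds shown, and "the series" means these compounds.

In a functional assay for agonist activity at G protein-coupled receptor 88 (Homo sapiens), read by HTRF and cAMP accumulation (a higher number here means that more compound is needed for the effect, a lower number that less compound is needed), compound 1 `CC[C@H](C)[C@H](N)CN(C(=O)[C@@H]1C[C@H]1c1ccc(Cl)cc1)c1ccc(-c2ccccc2)cc1` gives 4300 nM. Compound 2 `CC[C@H](C)[C@H](N)CN(C(=O)[C@@H]1C[C@H]1c1ccc(F)cc1)c1ccc(-c2ccccc2)cc1` gives 600 nM in this assay, and compound 3 `CC[C@H](C)[C@H](N)CN(C(=O)[C@@H]1C[C@H]1c1cccc(F)c1)c1ccc(-c2ccccc2)cc1` gives 560 nM. Compound 3 holds the lowest of the three numbers; its nearest neighbour is compound 2, within the scatter, and its furthest is compound 1, beyond it. The two halogen exchanges are modest steps: a 7.2-fold lower number from compound 1 to compound 2 (0.86 log units; beyond the scatter) and a 7.7-fold lower number from compound 1 to compound 3 (0.89 log units; beyond the scatter). Moving the fluoro from one ring position to the other is no step at all: a 1.1-fold lower number from compound 2 to compound 3 (0.03 log units; within the scatter).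

Compound 4 `CC[C@H](C)[C@H](N)CN(C(=O)[C@@H]1C[C@H]1c1cccc(C)c1)c1ccc(-c2ccccc2)cc1` differs from compound 3 by methyl in place of fluoro on an aromatic carbon. Among the measured compounds shown here, none of the measured steps involves a methyl, so nothing bears on this change directly. The closest comparison, the step from compound 2 to compound 3, shows that the position of a small aromatic substituent on this ring left the number within the scatter, while the chloro-to-fluoro steps show that the identity of that substituent can shift it modestly. A step of at most modest size, more likely none beyond the scatter, is expected: a 1.4-fold higher number from compound 3 to compound 4 (0.15 log units; within the scatter). Compound 4 is therefore estimated at 800 nM, within a range of 250 nM to 2500 nM.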

Compound 4, half-maximal effective concentration: 1200 nM
Estimate against measurement, compound 4: 1.5-fold (0.18 log units) below; the range from low to high includes it.
By their numbers in this assay, from the lowest: compounds 3, 2 and 4 (each within the scatter of the next, the first and the last beyond it); then compound 1.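

With the position held, the identity of the group on this aromatic carbon, meta to a large group, now registers: methyl in place of fluoro gives a 2.1-fold higher number from compound 3 to compound 4 (0.33 log units; beyond the scatter), whereas moving the fluoro left the number within the scatter. The separation from the fluoro compounds is not clean, since 3-methylphenyl in place of 4-fluorophenyl gives a 2.0-fold higher number from compound 2 to compound 4 (0.30 log units; within the scatter), and compound 4 is therefore set apart from compound 3 only, with the exchange sitting right at the edge of what can be told apart. Leaving fluoro behind does not by itself return the number to that of the chloro compound, as 3-methylphenyl in place of 4-chlorophenyl gives a 3.6-fold lower number from compound 1 to compound 4 (0.55 log units; beyond the scatter), so compound 1 stays highest of the four in this assay.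

No measurement among the compounds shown explains any of these steps. Open, going by these compounds, are whether the chloro penalty belongs to chloro itself or to its ring position, which 3-chlorophenyl and 4-methylphenyl would separate, and how larger or heteroatom-bearing groups at this position, such as methoxy, trifluoromethyl or an amine, would read.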